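This account rests on a few compounds, and the source may have more. Where it says the series, first, only, none or still open, it means among the compounds named here.

Working notes on the series. Among the compounds with values here, in an assay (Equus caballus) for inhibition of Thromboxane-A synthase (Homo sapiens), using microsomes (a higher number here means a weaker inhibitor, a lower number a stronger inhibitor), compound 2 `O=C(O)CCCC/C=C(\c1cccnc1)c1cccc([N+](=O)[O-])c1` gives 73 nM, the lowest of the three numbers so far; compound 1 `O=C(O)CCCC/C=C(/c1ccc(Br)cc1)c1cccnc1` gives 82 nM, a value within the scatter of compound 2, so no order between the two can be read. Compound 3 `NC(=O)CCCC/C=C(\c1ccccc1)c1cccnc1` gives 400 nM, a number beyond the scatter above that of compound 2. Compound 4 `O=C(O)CCCC/C=C(\c1cccnc1)c1cccc(F)c1` has not yet been measured in this assay. It differs from compound 2 in one place: fluoro in place of nitro on an aromatic carbon. Within the data shown here, no measured pair shows this change, so the step cannot be read from the data. A small step is expected, toward a slightly higher number, likely within the scatter, giving a 1.4-fold higher number from compound 2 to compound 4 (0.14 log units; within the scatter). Compound 4 is therefore estimated at 100 nM, in a range from 40 nM to 250 nM.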

Compound 4, half-maximal inhibitory concentration: 55 nM
For compound 4 the middle estimate is 1.8-fold (0.26 log units) above the measured one; the measured number falls inside the stated range.
By their numbers in this assay, from the lowest: compounds 4, 2 and 1 (each within the scatter of the next); then compound 3.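

In this assay, a step from nitro to fluoro on this aromatic carbon, meta to a large group, stays within the scatter: a 1.3-fold lower number from compound 2 to compound 4 (0.12 log units; within the scatter). A group with no hydrogen-bond acceptors by the count therefore reads the same as nitro at this place. The change of the whole aryl group, a 1.5-fold lower number from compound 1 to compound 4 (0.17 log units; within the scatter), is also within the scatter, so 3-fluorophenyl and 4-bromophenyl cannot be ordered, and no measurement here bears on why these values lie so close.

Still open, as far as these compounds go, is whether an amine or a methoxy group at this place would stay within the scatter. From the compounds shown here alone, a longer chain, or a tetrazole in place of the carboxylic acid, also remains open.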